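Chloro in place of hydrogen on the phenyl of compound 2

The compounds below may be only part of what the source reports. "The series", "measured", "known", "first", "only" and "open" are said of these compounds alone.

Compound 2 `COc1cc(/C=C/C(=O)c2cccc(-n3cc(-c4ccccc4)[nH]c3=O)c2)ccc1O` gives 1350 nM in a functional assay on 786-0 cells (Homo sapiens) for inhibition; a higher number here means a weaker inhibitor of growth, a lower number a stronger inhibitor of growth. Among the three measured compounds this is the lowest number, yet it sits within the scatter of both neighbours: compound 3 `COc1cc(/C=C/C(=O)c2cccc(-n3cc(-c4cc(OC)c(OC)c(OC)c4)[nH]c3=O)c2)cc(OC)c1OC` gives 1590 nM in this assay, and compound 1 `COc1cc(/C=C/C(=O)c2cccc(-n3cc(-c4ccc(Cl)cc4)[nH]c3=O)c2)cc(OC)c1OC` gives 2140 nM. Compound 4 `COc1cc(/C=C/C(=O)c2cccc(-n3cc(-c4ccc(Cl)cc4)[nH]c3=O)c2)ccc1O` differs from compound 2 by chloro in place of hydrogen on an aromatic carbon; cut one bond further out, the change reads phenyl to 4-chlorophenyl, sitting para to a large group. Within the data shown here, the only measured step that touches this part of the molecule is a 1.3-fold lower number from compound 1 to compound 3 (0.13 log units; within the scatter), which swaps 4-chlorophenyl for 3,4,5-trimethoxyphenyl and stays within the scatter. Among the measured compounds shown here, no measured pair shows phenyl against 4-chlorophenyl directly. On these data the author expects the step of a 1.1-fold higher number from compound 2 to compound 4 (0.05 log units; within the scatter) to stay within the scatter, with no clear direction. Compound 4 is therefore estimated at 1500 nM in this assay, in a range from 600 nM to 3800 nM.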

Compound 4, concentration for 50% growth inhibition: 2070 nM
Compound 4: the middle estimate sits 1.4-fold (0.14 log units) below what was measured, within the range that was stated.
By their numbers in this assay, from the lowest: compounds 2, 3, 4 and 1 (each within the scatter of the next).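

Among these compounds, the pair gives the first direct reading of phenyl against 4-chlorophenyl at this place: in this assay the step is a 1.5-fold higher number from compound 2 to compound 4 (0.19 log units; within the scatter), so chloro in place of hydrogen, para to a large group, produces no change that can be told from the scatter. Together with a 1.3-fold lower number from compound 1 to compound 3 (0.13 log units; within the scatter), this is a second step on this ring that stays within the scatter, so no step read here so far lies beyond it. No supporting measurement bears on this result.

From the compounds shown here alone, whether an amine, a carboxylic acid or a longer chain in place of chloro would give a step beyond the scatter remains open. The compounds shown also leave open whether the chloro step would read the same on a different core.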